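The compounds below may be only part of what the source reports. "The series", "measured", "known", "first", "only" and "open" are said of these compounds alone.

Compound 1 `CS(=O)(=O)c1ccc(Nc2ncc(F)c(Nc3nc4ccccc4s3)n2)cc1` gives 4980 nM in a functional assay on MDA-MB-231 cells (Homo sapiens) for antiproliferative activity, read by MTT assay, with a stated time of 48 h; a higher number here means a weaker inhibitor, a lower number a stronger inhibitor.
Compound 2 `Cc1ccc2nc(Nc3nc(Nc4ccc(S(C)(=O)=O)cc4)ncc3F)sc2c1` gives 14300 nM in this assay.
Compound 3 `CS(=O)(=O)c1ccc(Nc2ncc(F)c(Nc3nc4ccc(Cl)cc4s3)n2)cc1` gives 11100 nM in this assay.

Compound 3 stands second highest of the three numbers. Its nearest neighbour is compound 2, with a 1.3-fold lower number from compound 2 to compound 3 (0.11 log units; within the scatter) lying within the scatter, so no order between these two can be claimed. The furthest is compound 1, with a 2.2-fold higher number from compound 1 to compound 3 (0.35 log units; beyond the scatter) being beyond the scatter.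

Compound 4 `CS(=O)(=O)c1ccc(Nc2ncc(F)c(Nc3nc4ccc(F)cc4s3)n2)cc1` differs from compound 3 by fluoro in place of chloro on an aromatic carbon. Going by the values given here, the steps that bear on this are the two that reach compound 3 at the same carbon: a 2.2-fold higher number from compound 1 to compound 3 (0.35 log units; beyond the scatter), a modest rise on placing chloro where compound 1 carries hydrogen, and a 1.3-fold lower number from compound 2 to compound 3 (0.11 log units; within the scatter), within the scatter on exchanging methyl for chloro. The step of a 2.9-fold higher number from compound 1 to compound 2 (0.46 log units; beyond the scatter) shows that methyl at this carbon also raises the number. Among the compounds with values here, no measured step covers fluoro at this carbon, so the expectation rests on the pattern that both substituents tried so far gave a higher number than compound 1.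

For compound 4 a number between compound 1 and compound 3 is expected, with a 1.4-fold lower number from compound 3 to compound 4 (0.14 log units; within the scatter) as a modest lowering that may not exceed the scatter. The estimate for compound 4 in this assay is 8000 nM, with a range from 4000 nM to 16000 nM.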

Compound 4, half-maximal inhibitory concentration: 8900 nM
Beside the measured number, compound 4's estimate is 1.1-fold (0.05 log units) below it, within the range that was stated.
By their numbers in this assay, from the lowest: compounds 1, 4, 3 and 2 (each within the scatter of the next, the first and the last beyond it).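

In this assay, going by these compounds alone, fluoro is the first substituent at this carbon whose step from the hydrogen of compound 1 stays within the scatter (a 1.8-fold higher number from compound 1 to compound 4 (0.25 log units; within the scatter)), whereas the steps from compound 1 to the methyl and chloro compounds lie beyond it. Fluoro cannot be separated from either of those groups here, neither from chloro (a 1.2-fold lower number from compound 3 to compound 4 (0.10 log units; within the scatter)) nor from methyl (a 1.6-fold lower number from compound 2 to compound 4 (0.21 log units; within the scatter)), so compounds 2, 3 and 4 stand without any order among them. No measured evidence is available to explain these numbers.

As far as these compounds go, it remains open whether another group at this carbon, such as an amine, a carboxylic acid or a methoxy group, would give a number beyond the scatter of compound 1 in either direction. The compounds shown also keep the rest of the core of compound 1 unchanged, so they say nothing about whether the same substituents would behave alike on a core altered elsewhere.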